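From Methoxyphenyl to Dichlorophenyl on a Shared Core

The source may hold more compounds than are shown below. What is called first, only, known or untested is meant among the compounds shown, and "the series" means these compounds.

For the measured compounds named here, in a functional assay on HepG2 cells (Homo sapiens) for cytotoxicity, read by MTT assay, with a stated time of 72 h (a lower number here means a stronger inhibitor, a higher number a weaker inhibitor), compound 2 `CNC(=O)c1cc(Oc2ccc(C3=NNC(c4ccc(OC)cc4)C3)cc2)ccn1` gives 9640 nM, the higher of the two numbers measured so far. Going by the values given here, the only other measured compound, compound 1 `CNC(=O)c1cc(Oc2ccc(C3=NNC(c4cccc(Br)c4)C3)cc2)ccn1`, gives 1850 nM. Compound 3 `CNC(=O)c1cc(Oc2ccc(C3=NNC(c4cccc(Cl)c4Cl)C3)cc2)ccn1` keeps the shared core and changes one group: 2,3-dichlorophenyl in place of 4-methoxyphenyl on a saturated ring carbon. In words, this places 2,3-dichlorophenyl in place of 4-methoxyphenyl on a saturated ring carbon.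

Among the compounds with values here, one measured step bears on this change. At that same carbon, the move from 3-bromophenyl to 4-methoxyphenyl gave a 5.2-fold higher number from compound 1 to compound 2 (0.72 log units; beyond the scatter), a modest step beyond the scatter. Within the data shown here, compound 3 again carries a halogenated phenyl, so a partial return towards compound 1 is expected, though no chlorinated compound has been measured. The expected change is a 3.4-fold lower number from compound 2 to compound 3 (0.54 log units; beyond the scatter). For compound 3 the estimated value is 2800 nM, with an expected range from 1000 nM to 7500 nM.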

Compound 3, half-maximal inhibitory concentration: 4990 nM
Estimate against measurement, compound 3: 1.8-fold (0.25 log units) below, and the stated range covers the measured number.
By their numbers in this assay, from the lowest: compound 1; then compounds 3 and 2 (each within the scatter of the next).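

In this assay, replacing 4-methoxyphenyl with 2,3-dichlorophenyl on this saturated ring carbon gives a 1.9-fold lower number from compound 2 to compound 3 (0.29 log units; within the scatter) and so does not separate the two groups. A halogenated phenyl at this position is therefore not enough on its own to reach the number of compound 1, as the comparison with 3-bromophenyl shows a 2.7-fold higher number from compound 1 to compound 3 (0.43 log units; beyond the scatter) and this gap lies beyond the scatter. No measurement is available that would explain these differences.

The compounds shown leave open whether the gap between compound 1 and compound 3 follows the kind of halogen, the number of halogens or their placement on the phenyl ring. They also leave open how a phenyl bearing an amine or a carboxylic acid would behave at this carbon.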